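Furan-2-yl in place of phenyl on the shared core

A few compounds are considered here, and "the series" means these few. Any claim that something is new, unique, unknown or untested is made for them only; others in the source may bear on it.

Measured so far in a functional assay on A549 cells (Homo sapiens) for cytotoxicity, read by MTT assay; a higher number here means a weaker inhibitor, a lower number a stronger inhibitor: compound 1 `CCOC(=O)C12C(=O)OCC=C1COC2c1ccccc1` gives > 1000000 nM; compound 2 `CCOC(=O)C12C(=O)OCC=C1COC2c1cc(OC)cc(OC)c1` gives > 1000000 nM; compound 3 `CCOC(=O)C12C(=O)OCC=C1COC2c1cc(OC)c(OC)c(OC)c1` gives 13300 nM.

Compound 1 stands at a limit of this assay, not at a number. Compound 2 likewise returns only a limit. Among the compounds with values here, compound 3 is the only member of the series with a numeric value. Within the data shown here, the one step between compounds that differ in a single place is an at least 75-fold lower number from compound 2 to compound 3 (1.87 log units; beyond the scatter), which adds a methoxy group on an aromatic carbon and moves the value from the limit of > 1000000 nM in this assay, at which 2 of the 3 values shown sit, down to a measurable number.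

Compound 4 `CCOC(=O)C12C(=O)OCC=C1COC2c1ccco1` is not yet measured. It differs from compound 1 by furan-2-yl in place of phenyl on a saturated ring carbon. Among the measured compounds shown here, no measured step touches the aryl group itself; the only step recorded concerns a methoxy substituent on that group, so it gives no guide to swapping phenyl for furan-2-yl. With compound 1 at the limit and nothing pointing toward a gain, the expected step of a number no higher from compound 1 to compound 4 (the limit leaves the size open) is none beyond the scatter, and compound 4 is most likely to return a limit again. The estimate for compound 4 in this assay is 1000000 nM, with a range from 300000 nM to 3000000 nM.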

Compound 4, half-maximal inhibitory concentration: > 1000000 nM
Compound 4: no number, only a limit; the forecaster's own chance of this, stated with the estimate: 80%; the middle value lies on the limit itself.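

Compound 4 gives > 1000000 nM, which is a limit and not a number. Compound 1 also sits at a limit, so no step can be read between compound 1 and compound 4. The compounds shown leave open whether furan-2-yl and phenyl on the shared core differ at all in this assay.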